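The compounds below may be only part of what the source reports. "The series", "measured", "known", "first", "only" and "open" are said of these compounds alone.

Measured in a functional assay on HT-1080 cells (Homo sapiens), read by transwell migration, with a stated time of 24 h, tested at 1 uM; a lower number here means a stronger effect, a higher number a weaker effect of the compound at the concentration tested:

Compound 1 `CC(=O)OCc1ccc2oc(=O)c(C(=O)Oc3cccc(Cl)c3)cc2c1`: 49.1%
Compound 2 `CC(=O)OCc1ccc2oc(=O)c(C(=O)Oc3cccc(Br)c3)cc2c1`: 21.8%
Compound 3 `CC(=O)OCc1ccc2oc(=O)c(C(=O)N(C)c3ccccc3Cl)cc2c1`: 62.8%

Compound 2 gives the lowest number of the three, meaning the strongest effect on migration. The step of a number 27.3 percentage points lower from compound 1 to compound 2 (beyond the scatter) separates it from its nearest neighbour, and the step of a number 41 percentage points higher from compound 2 to compound 3 (beyond the scatter) from the furthest. Compound 4 `CCCCCCC(=O)OCc1ccc2oc(=O)c(C(=O)Oc3cccc(Br)c3)cc2c1` differs from compound 2 in one place: pentyl in place of hydrogen on a saturated chain carbon bound to a carbonyl carbon. None of the three measured steps touches this chain; each of them alters the group on the carbonyl carbon or the halogen on its ring. Going by the values given here, no measured step therefore bears on this change, and no step beyond the scatter is expected in this assay. Compound 4 is estimated at 25%, between 8% and 45%, an expected step of a number 3.2 percentage points higher from compound 2 to compound 4 (within the scatter).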

Compound 4, a percentage reported as activity, at one concentration (the size of the read-out at that concentration, not a potency): 55.6%
The estimate for compound 4 lay 30.6 percentage points below the measured number; measured number outside the range, above it.
By their numbers in this assay, from the lowest: compound 2; then compounds 1, 4 and 3 (each within the scatter of the next, the first and the last beyond it).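

In this assay the change from methyl to hexyl brings a number 33.8 percentage points higher from compound 2 to compound 4 (beyond the scatter) and so a weaker effect at the concentration tested. Going by these compounds alone, the saturated chain carbon bound to a carbonyl carbon is therefore no silent spot: this end of the molecule affects the read-out, which the earlier compounds could not show, as all of them carry the same acetoxy group. As far as these compounds go, whether a propyl chain would keep the effect of compound 2, or an amine or carboxylic acid at the chain end would change it, stays open. Nothing available explains why the hexyl chain weakens the effect.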